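Same acyl-chain change, carried to a second core

This account rests on a few compounds, and the source may have more. Where it says the series, first, only, none or still open, it means among the compounds named here.

Compound 1 `COc1cc(N(C)CCN(C)C)c(NC(=O)/C=C\C(C)C)cc1Nc1nccc(-c2cn(C)c3ccccc23)n1` and compound 2 `CCC/C=C\C(=O)Nc1cc(Nc2nccc(-c3cn(C)c4ccccc34)n2)c(OC)cc1N(C)CCN(C)C` share one core and differ only in the acyl chain. In a functional assay on A549 cells (Homo sapiens) for antiproliferative activity, read by MTT assay, with a stated time of 72 h (on this read-out lower numbers stand for stronger inhibition and higher numbers for weaker inhibition), compound 1 gives 612 nM, and compound 2 gives 808 nM. The change between them is propyl in place of isopropyl on a double-bonded chain carbon bound to a double-bonded chain carbon The step it made was a 1.3-fold higher number from compound 1 to compound 2 (0.12 log units; within the scatter), so on this pair the two chains cannot be told apart.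

Compound 3 `COc1cc(N(C)CCN(C)C)c(NC(=O)/C=C\C(C)C)cc1Nc1ncc(C#N)c(-c2cn(C)c3ccc(F)cc23)n1` carries a different core; how that core differs from the core of compound 1 is not broken down here. In this assay compound 3 gives 185 nM, the lowest of the three numbers, with compound 1 the nearest at a step beyond the scatter and compound 2 the furthest.

Compound 4 `CCC/C=C\C(=O)Nc1cc(Nc2ncc(C#N)c(-c3cn(C)c4ccc(F)cc34)n2)c(OC)cc1N(C)CCN(C)C` is not yet measured. It stands to compound 3 as compound 2 stands to compound 1: the change is propyl in place of isopropyl on a double-bonded chain carbon bound to a double-bonded chain carbon This is the same change as before, at the same place, now made on the core of compound 3.

Because the earlier step of a 1.3-fold higher number from compound 1 to compound 2 (0.12 log units; within the scatter) stayed within the scatter, the step expected here is also small, about a 1.3-fold higher number from compound 3 to compound 4 (0.11 log units; within the scatter), a mild rise in the number or none. On these data alone, whether the second core shifts the size of the step is unknown, so the expected range is kept broad. Compound 4 is therefore estimated to give 240 nM in this assay, between 120 nM and 500 nM.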

Compound 4, half-maximal inhibitory concentration: 741 nM
The estimate for compound 4 lay 3.1-fold (0.49 log units) below the measured number; the measured number lies above the stated range.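

In this assay, the swap of isopropyl for propyl, which left no readable difference on the core of compound 1, gave a 4.0-fold higher number from compound 3 to compound 4 (0.60 log units; beyond the scatter) on the core of compound 3. The size of the step therefore did not carry over from one core to the other, so in this series a result for this change on one core cannot simply be transferred to the other: the same change on two cores in this assay, a 1.3-fold higher number (0.12 log units; within the scatter) from compound 1 to compound 2 and a 4.0-fold higher number (0.60 log units; beyond the scatter) from compound 3 to compound 4, 3.0-fold (0.48 log units) apart, beyond the scatter of two such steps This rests on a single pair of compounds for each core in one cell assay, and it does not show which feature of the core of compound 3 goes with the larger step, nor does it establish a general rule for other acyl chains or other cores.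

The core of compound 3 carries both a nitrile and a fluorine, and the compounds shown leave open whether either group alone would bring out the larger step, or whether both are needed. They also leave open how a chain ending in cyclopropyl, or a longer chain such as butyl, would behave at the same place on each of the two cores.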